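This account rests on a few compounds, and the source may have more. Where it says the series, first, only, none or still open, it means among the compounds named here.

Measured in an in vitro assay on CHO cells for displacement of a labelled ligand from Bombesin receptor subtype-3 (Homo sapiens), read by scintillation counting, with a stated time of 2 h; on this read-out lower numbers stand for stronger inhibition and higher numbers for weaker inhibition:
compound 1 `CCC(C)(C)Cc1c[nH]c(CCc2ccc(-n3cccn3)cc2)n1`, where compound 1 gives 33 nM
compound 2 `CCC(C)(C)Cc1c[nH]c(CCc2ccc(-c3cnccn3)cc2)n1`, where compound 2 gives 51 nM
compound 3 `CCC(C)(C)Cc1c[nH]c(CCc2ccc(-c3cccc(N)n3)cc2)n1`, where compound 3 gives 7.3 nM

Compound 3 holds the lowest number of the three, and both gaps to it lie beyond the scatter: a 4.5-fold lower number from compound 1 to compound 3 (0.66 log units; beyond the scatter) and a 7.0-fold lower number from compound 2 to compound 3 (0.84 log units; beyond the scatter). Between the other two the difference is small and within the scatter: a 1.5-fold higher number from compound 1 to compound 2 (0.19 log units; within the scatter).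

Compound 4 `CCC(C)(C)Cc1c[nH]c(CCc2ccc(-c3cnsc3)cc2)n1` is the next member, not yet measured in this assay. Relative to compound 3 the change is 1,2-thiazol-4-yl in place of 6-aminopyridin-2-yl on an aromatic carbon. The measured steps that bear on this are the two arrivals at compound 3, a 4.5-fold lower number from compound 1 to compound 3 (0.66 log units; beyond the scatter) and a 7.0-fold lower number from compound 2 to compound 3 (0.84 log units; beyond the scatter), each a modest lowering that came with the 6-aminopyridin-2-yl group and its 1 hydrogen-bond donor. The entering 1,2-thiazol-4-yl has 0 hydrogen-bond donors, as do the groups of compound 1 and compound 2, which sit close together in this assay. For compound 4 the expected step is therefore a modest rise back toward those two, a 4.8-fold higher number from compound 3 to compound 4 (0.68 log units; beyond the scatter). Compound 4 is estimated at 35 nM in this assay, with a range from 12 nM to 100 nM.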

Compound 4, half-maximal inhibitory concentration: 10 nM
Compound 4: the middle estimate sits 3.5-fold (0.54 log units) above what was measured; measured number outside the range, below it.
By their numbers in this assay, from the lowest: compounds 3 and 4 (each within the scatter of the next); then compounds 1 and 2 (each within the scatter of the next).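

In this assay, the step from the 6-aminopyridin-2-yl group to the 1,2-thiazol-4-yl group on this aromatic carbon, para to a large group, stays within the scatter (a 1.4-fold higher number from compound 3 to compound 4 (0.14 log units; within the scatter)), so a hydrogen-bond donor in this group is not required for a number at the low end of this set. The groups without a donor also no longer fall together, since the 1,2-thiazol-4-yl group separates from both others beyond the scatter (a 5.1-fold lower number from compound 2 to compound 4 (0.71 log units; beyond the scatter); a 3.3-fold lower number from compound 1 to compound 4 (0.52 log units; beyond the scatter)), and compound 4 goes against any reading that ties the lower numbers to the donor alone. Nothing available on these compounds accounts for the match between compound 3 and compound 4 or for the gaps to compound 1 and compound 2.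

The compounds shown do not separate the contribution of the amine in compound 3 from that of its pyridine ring, a question that a plain pyridin-2-yl group would address. Also open, going by these compounds, is whether an amine on the 1,2-thiazol-4-yl ring would lower the number further or leave it unchanged.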